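This account rests on a few compounds, and the source may have more. Where it says the series, first, only, none or still open, it means among the compounds named here.

Measured compounds in a functional assay on SGC-7901 cells (Homo sapiens) for inhibition, read by MTT assay, with a stated time of 72 h; a lower number here means a stronger inhibitor, a higher number a weaker inhibitor:
- compound 1, `CC(C)C(=O)Nc1cccc(C(=O)/C=C2/C(=O)Nc3ccccc32)c1`: 8600 nM
- compound 2, `O=C1Nc2ccccc2/C1=C\C(=O)c1ccccc1F`: 17400 nM
- compound 3, `O=C1Nc2ccccc2/C1=C\C(=O)c1ccccc1Br`: 13100 nM

Compound 1 gives the lowest of the three numbers; its gap to compound 3 lies within the scatter, its gap to compound 2 lies beyond it. Among the compounds with values here, the only step between measured compounds that differ in one place is a 1.3-fold lower number from compound 2 to compound 3 (0.12 log units; within the scatter); it concerns the substituent on the aryl ring of the ketone and not the amide side.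

Compound 4, `C=CC(=O)Nc1cccc(C(=O)/C=C2/C(=O)Nc3ccccc32)c1`, has not yet been measured in this assay. Against compound 1 the change is vinyl in place of isopropyl on a carbonyl carbon. Within the data shown here, no measured pair changes the group on this carbonyl carbon, so no step bears directly on the move from isopropyl to vinyl, and the one step that is known, from fluoro to bromo, is within the scatter. On that basis no shift beyond the scatter is expected, and compound 4 is estimated at 6500 nM with a range from 2500 nM to 20000 nM, which corresponds to an expected step of a 1.3-fold lower number from compound 1 to compound 4 (0.12 log units; within the scatter).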

Compound 4, half-maximal inhibitory concentration: 5700 nM
For compound 4 the middle estimate is 1.1-fold (0.06 log units) above the measured one; the measured number falls inside the stated range.
By their numbers in this assay, from the lowest: compounds 4, 1, 3 and 2 (each within the scatter of the next, the first and the last beyond it).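

In this assay, within the data shown here, vinyl in place of isopropyl on a carbonyl carbon whose other neighbour is the amide-type nitrogen gives a 1.5-fold lower number from compound 1 to compound 4 (0.18 log units; within the scatter) and so adds a first measured pair at this position. Compound 1 and compound 4 cannot be ranked against each other, so this one change leaves the number within the scatter. No available data explain the step or show whether the double bond of the vinyl group plays any part.

Still open, on these data alone, is whether another group on this carbonyl carbon, such as ethyl, a longer chain, phenyl or a chain ending in an amine, would move the number beyond the scatter in this assay. The compounds shown also leave open how a halogen such as fluoro or bromo on the aromatic ring would read alongside the vinylcarbonyl amino group.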